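Replacing an anilide with a dimethylamide in a DGAT1 inhibitor

The source may hold more compounds than are shown below. What is called first, only, known or untested is meant among the compounds shown, and "the series" means these compounds.

Among the measured compounds shown here, compound 1, `Cn1c(OCC(C)(C)C(=O)Nc2ccccc2)nnc1-c1ccc(NC(=O)c2ccc3ccccc3c2)cc1`, stands at the lower of the two numbers measured so far in an assay on 3T3-L1 cells for inhibition of diacylglycerol O-acyltransferase 1 (Mus musculus); a lower number here means a stronger inhibitor, a higher number a weaker inhibitor; in this assay compound 1 gives 220 nM. For the measured compounds named here, the only other measured compound, compound 2, `Cc1cc(NC(=O)c2ccc3ccccc3c2)ccc1-c1cnc(OCC(C)(C)C(=O)O)cn1`, differs from it in several places at once, and in this assay compound 2 gives 2160 nM, a gap beyond the scatter of the method. Going by the values given here, no two measured compounds differ in a single spot, so the weight of any one change is still unknown.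

Compound 3, `CN(C)C(=O)C(C)(C)COc1nnc(-c2ccc(NC(=O)c3ccc4ccccc4c3)cc2)n1C`, is compound 1 with one alteration: dimethylamino in place of anilino on a carbonyl carbon. Among the compounds with values here, since no measured pair shows this kind of change, the expectation can only be rough: the step from compound 1 to compound 3 is expected to be a modest loss, a 2.7-fold higher number from compound 1 to compound 3 (0.44 log units; beyond the scatter). Compound 3 is therefore estimated at 600 nM in this assay, with a range from 150 nM to 2500 nM.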

Compound 3, half-maximal inhibitory concentration: 440 nM
Estimate against measurement, compound 3: 1.4-fold (0.13 log units) above; the range from low to high includes it.
By their numbers in this assay, from the lowest: compounds 1 and 3 (each within the scatter of the next); then compound 2.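

In this assay the step at this position reads a 2.0-fold higher number from compound 1 to compound 3 (0.30 log units; within the scatter) and so compound 1 and compound 3 cannot be told apart. The carbonyl carbon can therefore carry dimethylamino instead of anilino with no difference this method can detect, even though the change removes the six-membered aromatic ring and the amide hydrogen, so neither feature is required for a value in this range on this core. No measurement shown here explains why the two groups give matching results.

As far as these compounds go, it remains open how other groups on the same carbonyl carbon would compare, such as methylamino, pyrrolidin-1-yl or morpholin-4-yl. Also unresolved is whether this swap would be just as well tolerated on a different core.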